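The source may report more compounds than this note shows. Statements on the series, on what has been measured and on what is new or still open speak of the compounds shown alone.

Compounds measured so far:
compound 1, `COCCNS(=O)(=O)CCn1ccnc1[N+](=O)[O-]`, in a functional assay on HCT-116 cells (Homo sapiens) for cytotoxicity, read by sulforhodamine B assay, with stated times of 4 h and 5 days (on this read-out lower numbers stand for stronger inhibition and higher numbers for weaker inhibition), 400000 nM;
compound 2, `COCCNS(=O)(=O)CCn1cnc([N+](=O)[O-])c1`, in this assay a limit of > 5300000 nM;
compound 3, `COCCCNS(=O)(=O)CCn1c([N+](=O)[O-])cnc1C`, in this assay 3700000 nM.

Compound 3 has the highest of the two numbers reported here; its nearest neighbour, compound 1, sits at a lower number, and the gap between them lies beyond the usual scatter. Compound 2 gives only a limit, (the limit of > 5300000 nM in this assay, at which 1 of the 3 values shown sits), and not a number.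

Compound 4, `Cc1ncc([N+](=O)[O-])n1CCS(=O)(=O)N1CCOCC1`, has not been measured. It differs from compound 3 by morpholin-4-yl in place of (3-methoxypropyl)amino on a sulfonyl sulfur. Within the data shown here, no step between measured compounds covers this change, so there is nothing to set its size or direction from. Compound 4 is therefore expected to sit close to compound 3, with a step of a 1.2-fold lower number from compound 3 to compound 4 (0.09 log units; within the scatter) that is within the scatter. In this assay compound 4 is estimated at 3000000 nM, between 700000 nM and 13000000 nM.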

Compound 4, half-maximal inhibitory concentration: 38000 nM
Estimate against measurement, compound 4: 79-fold (1.90 log units) above; measured number outside the range, below it.
By their numbers in this assay, from the lowest: compound 4; then compound 1; then compound 3. At a limit, above all of these: compound 2.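

In this assay, putting morpholin-4-yl in place of (3-methoxypropyl)amino on a sulfonyl sulfur gives a 97-fold lower number from compound 3 to compound 4 (1.99 log units; beyond the scatter), which shows that this position can strongly move the read-out. The two groups have the same heavy-atom count, yet they differ in the ring and in the hydrogen-bond donor that morpholin-4-yl lacks. Nothing measured here accounts for the size of this step.

As far as these compounds go, whether the ring or the missing donor matters more stays open, and a piperidine ring or a tertiary open-chain amine on that sulfur would bear on this. From the compounds shown here alone, whether morpholin-4-yl acts alike on the cores of compound 1 and compound 2 also stays open.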